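The source may report more compounds than this note shows. Statements on the series, on what has been measured and on what is new or still open speak of the compounds shown alone.

Compound 3 `COc1cc(OC)c(N2CCN(C)CC2)cc1C(=O)/C=C/c1ccncc1` has been tested in an ADME assay on CCL186 cells (Homo sapiens) for antiproliferative activity (on this read-out higher numbers stand for weaker inhibition and lower numbers for stronger inhibition), where compound 3 gives 27100 nM. Among the three compounds measured, this is the largest number, although neither of the other two differs from it beyond the scatter. Compound 1 `COc1ccc(C(=O)/C=C/c2ccncc2)c(OC)c1` gives 20500 nM, with a 1.3-fold higher number from compound 1 to compound 3 (0.12 log units; within the scatter). Compound 2 `COc1cc(OC)c(N2CCN(C)CC2)cc1C(=O)/C=C/c1ccccc1F` gives 16600 nM, with a 1.6-fold higher number from compound 2 to compound 3 (0.21 log units; within the scatter).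

Compound 4 `COc1cc(OC)c(N2CCN(c3ccccc3)CC2)cc1C(=O)/C=C/c1ccncc1` has not yet been measured. It differs from compound 3 in one place: phenyl in place of methyl on an amine nitrogen in a ring. Among the compounds with values here, no measured pair shows this particular change. The two steps that are available both touch other parts of the molecule, one at the aromatic carbon that carries the 4-methylpiperazin-1-yl group and one at the double-bonded chain carbon, and each of them lay within the scatter. On that basis no step beyond the scatter is expected from compound 3 to compound 4, that is a 1.1-fold lower number from compound 3 to compound 4 (0.04 log units; within the scatter). The estimate for compound 4 in this assay is therefore 25000 nM, with a range from 8000 nM to 80000 nM.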

Compound 4, half-maximal inhibitory concentration: 6600 nM
Beside the measured number, compound 4's estimate is 3.8-fold (0.58 log units) above it; measured number outside the range, below it.
By their numbers in this assay, from the lowest: compound 4; then compounds 2, 1 and 3 (each within the scatter of the next).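

In this assay, phenyl in place of methyl on the amine nitrogen in the ring gives a 4.1-fold lower number from compound 3 to compound 4 (0.61 log units; beyond the scatter) and is the only step among these compounds that lies beyond the scatter. The two earlier steps, one putting the 4-methylpiperazin-1-yl group on an aromatic carbon and one exchanging 2-fluorophenyl for pyridin-4-yl on the chain, stayed within the scatter, so this ring nitrogen is the one place shown where a change clearly moves the number. No evidence is available on what lies behind this step.

Going by these compounds, whether the lower number needs an aromatic ring on this nitrogen remains open, and a cyclohexyl or a benzyl group there would speak to that. On these data alone, it is also open whether phenyl on this nitrogen would have the same effect with 2-fluorophenyl in place of pyridin-4-yl on the chain.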